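This account rests on a few compounds, and the source may have more. Where it says the series, first, only, none or still open, it means among the compounds named here.

In a functional assay on SK-MEL-28 cells (Homo sapiens) for inhibition, read by sulforhodamine B assay, with a stated time of 48 h (on this read-out higher numbers stand for weaker inhibition of growth and lower numbers for stronger inhibition of growth), compound 1 (`CN1CCN(CCCOc2cccc3nc(Nc4ccc(Cl)c(C(F)(F)F)c4)ccc23)CC1`) gives 1390 nM and compound 2 (`CC(C)c1ccc(Nc2ccc3c(OCCCN4CCN(C)CC4)cccc3n2)cc1`) gives 1890 nM while compound 3 (`CN1CCN(CCCOc2cccc3nc(Nc4ccc(F)c(F)c4)ccc23)CC1`) gives 1080 nM with no gap beyond the scatter among them. Compound 3 therefore stands level with both others. Compound 4 (`CN1CCN(CCCOc2cccc3nc(Nc4cccc(Cl)c4)ccc23)CC1`) differs from it in one place, with 3-chlorophenyl in place of 3,4-difluorophenyl on a nitrogen on an aromatic ring. Three measured exchanges at that place bear on this, namely a 1.4-fold higher number from compound 1 to compound 2 (0.13 log units; within the scatter) and a 1.3-fold lower number from compound 1 to compound 3 (0.11 log units; within the scatter) and also a 1.8-fold lower number from compound 2 to compound 3 (0.24 log units; within the scatter) and none leaves the scatter. No step beyond the scatter is therefore expected in this assay for this exchange. The estimated step is a 1.2-fold higher number from compound 3 to compound 4 (0.08 log units; within the scatter) and would stay small. For compound 4 the expected value is 1300 nM with 700 nM to 2400 nM as its estimated range.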

Compound 4, concentration for 50% growth inhibition: 1650 nM
Compound 4: the middle estimate sits 1.3-fold (0.10 log units) below what was measured; low and high end bracket the measured number.
By their numbers in this assay, from the lowest: compounds 3, 1, 4 and 2 (each within the scatter of the next).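

In this assay the change to 3-chlorophenyl leaves the number level, with a 1.5-fold higher number from compound 3 to compound 4 (0.18 log units; within the scatter) and a 1.1-fold lower number from compound 2 to compound 4 (0.06 log units; within the scatter) and also a 1.2-fold higher number from compound 1 to compound 4 (0.07 log units; within the scatter) all lying within the scatter. Four different substituted phenyl groups on a nitrogen on an aromatic ring now stand level, so swapping one for another at this place has yet to produce a step beyond the scatter. On these data alone, whether a carboxylic acid or an amine on the phenyl, or a pyridine ring in its place, would separate from these four stays open. Nothing given here explains why these groups stand level.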